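Cytotoxicity limits and the pyridin-3-yl exchange

This account rests on a few compounds, and the source may have more. Where it says the series, first, only, none or still open, it means among the compounds named here.

In an ADME assay on THP-1 cells (Homo sapiens) for cytotoxicity, read by MTT assay (a lower number here means that less compound is tolerated, a higher number that more compound is tolerated), compound 1 (`Cc1nc(-c2cccnc2)sc1-c1nnc(-c2cccc(Cl)c2Cl)o1`) gives > 100 ug/mL as a limit, not a number. Compound 2 (`Cc1ccc(-c2nnc(-c3sc(-c4cccnc4)nc3C)o2)cc1`) gives > 100 ug/mL as a limit too. Compound 2 thus stands at the limit of > 100 ug/mL in this assay, at which 2 of the 2 values shown sit, and has no number of its own.

Compound 3 (`Cc1nc(-c2cccnc2)sc1-c1nnc(-c2cccnc2)o1`) carries pyridin-3-yl in place of 4-methylphenyl on an aromatic carbon of the five-membered aromatic ring with 2 nitrogen and 1 oxygen (pyridin-3-yl in place of 4-methylphenyl on an aromatic carbon). Among the measured compounds shown here, the one measured step at this place is a step that the two limits leave unreadable from compound 1 to compound 2 with 4-methylphenyl in place of 2,3-dichlorophenyl, so it offers no size to carry over. On that step, no change beyond the scatter is expected in this assay and no direction can be assigned. The estimated step is a step that the limit leaves unreadable from compound 2 to compound 3 for this pair. Compound 3 is expected near 150 ug/mL with an estimated range of 70 ug/mL to 400 ug/mL and a high expected chance that only a limit is reported.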

Compound 3, half-maximal cytotoxic concentration: > 100 ug/mL
Compound 3: a limit, no number; the forecaster's own chance of this, stated with the estimate: 80%; the middle value is on the limit's open side.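

No step can be read among compound 1, compound 2 and compound 3 in this assay, because all three give a limit and no number: the limit of > 100 ug/mL in this assay, at which 3 of the 3 values shown sit.

The compounds shown leave open whether exchanging these groups on the shared core changes cytotoxicity at all.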